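Replacing a Cyclopentyl Ring by an Open Butyl Chain

The compounds below may be only part of what the source reports. "The series", "measured", "known", "first", "only" and "open" are said of these compounds alone.

Measured compounds:
compound 1, `COc1ccc(N)c(C(=O)CCNC(=O)C2CCC2)c1`: 92.2%
compound 2, `COc1ccc(N)c(C(=O)CCNC(=O)c2ccccc2)c1`: 97.2%
compound 3, `COc1ccc(N)c(C(=O)CCNC(=O)C2CCCC2)c1`: 96.3%

All three compounds share one core and differ only in the group on the amide carbonyl carbon. In a functional assay for inhibition of kynurenine 3-monooxygenase (Rattus norvegicus), tested at 1 mM (on this read-out higher numbers stand for more inhibition at the one concentration tested (going by the name of the read-out) and lower numbers for less inhibition), compound 3 gives 96.3% and holds the second highest of the three numbers; its nearest neighbour is compound 2, with a number 0.9 percentage points lower from compound 2 to compound 3 (within the scatter), and its furthest is compound 1, with a number 4.1 percentage points higher from compound 1 to compound 3 (within the scatter), so all three values sit within the usual scatter of one another.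

Compound 4, `CCCCC(=O)NCCC(=O)c1cc(OC)ccc1N`, has not yet been measured. It differs from compound 3 as follows: butyl in place of cyclopentyl on a carbonyl carbon.

Among the measured compounds shown here, two measured steps bear on this change, since both alter the same carbonyl substituent: a number 4.1 percentage points higher from compound 1 to compound 3 (within the scatter) and a number 0.9 percentage points lower from compound 2 to compound 3 (within the scatter). Neither the growth from a four-membered to a five-membered ring nor the swap of an aromatic for a saturated ring moved the read-out beyond the scatter. On this basis the step in this assay from compound 3 to compound 4 is expected to be a number 2.3 percentage points lower from compound 3 to compound 4 (within the scatter), that is, no change beyond the scatter. Compound 4 is therefore estimated to give 94%, with a range from 85% to 99%.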

Compound 4, a percentage reported as inhibition, at one concentration (the size of the read-out at that concentration, not a potency): 97.2%
Estimate against measurement, compound 4: 3.2 percentage points below; low and high end bracket the measured number.
By their numbers in this assay, from the lowest: compounds 1, 3, 2 and 4 (each within the scatter of the next).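

In this assay, among the compounds shown here, the earlier compounds all carried a ring on the carbonyl carbon, and butyl in place of cyclopentyl gives a number 0.9 percentage points higher from compound 3 to compound 4 (within the scatter), so within this set a ring at this position is not required to keep the read-out. The open chain also stands level with the other two ring groups, with no change at the digits printed from compound 2 to compound 4 (within the scatter) and a number 5 percentage points higher from compound 1 to compound 4 (within the scatter), which leaves the three rings and the butyl chain indistinguishable on this read-out and none of the four compounds going against that picture. Nothing measured here explains why the read-out stays the same when the ring is opened.

From the compounds shown here alone, each number is the size of the inhibition at one concentration and not a potency, so it remains open whether butyl, cyclopentyl, cyclobutyl and phenyl would separate in a full concentration series. It also remains open whether the number would stay level with other groups on the carbonyl carbon, for instance a longer chain, a methyl group, an amine or a carboxylic acid, since all four groups shown consist of carbon and hydrogen only.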